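Methoxy at the Methyl Position of a Fused Purine-like Core

The source may hold more compounds than are shown below. What is called first, only, known or untested is meant among the compounds shown, and "the series" means these compounds.

Measured compounds:
- compound 1, `Cc1nc(N)c2nc(O)n(Cc3ccccc3)c2n1`, 1 uM
- compound 2, `CCCCNc1nc(N)c2nc(O)n(Cc3ccccc3)c2n1`, 1 uM
- compound 3, `Nc1ncnc2c1nc(O)n2Cc1ccccc1`, 10 uM

These three compounds share one core and differ only in the group on an aromatic carbon of the six-membered ring, the carbon that sits between two ring nitrogen atoms. In a functional assay (spleen, spleen) for activation, with Mus musculus as the target (a higher number here means that more compound is needed for the effect, a lower number that less compound is needed), compound 1 gives 1 uM. Compound 2 gives 1 uM, so compound 1 and compound 2 stand level within the scatter, with no change at the digits printed from compound 1 to compound 2 (within the scatter). Compound 3 gives 10 uM; the step of a 10-fold higher number from compound 1 to compound 3 (1.00 log units; beyond the scatter) and the step of a 10-fold higher number from compound 2 to compound 3 (1.00 log units; beyond the scatter) show that removing the group at this carbon costs a modest amount.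

Compound 4, `COc1nc(N)c2nc(O)n(Cc3ccccc3)c2n1`, is not yet measured. It differs from compound 1 as follows: methoxy in place of methyl on an aromatic carbon. Both steps that bear on this position point the same way: a methyl and a butylamino are held equal, while a bare hydrogen is worse. A methoxy keeps a group at this carbon, so no step beyond the scatter is expected in this assay.

Compound 4 is therefore estimated at 1 uM, with a range from 0.3 uM to 3 uM, meaning an expected step of no change at the digits printed from compound 1 to compound 4 (within the scatter).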

Compound 4, minimum effective concentration: 0.1 uM
Compound 4: middle estimate off by 10-fold (1.00 log units), on the high side; the measured number lies below the stated range.
By their numbers in this assay, from the lowest: compound 4; then compounds 1 and 2 (each within the scatter of the next); then compound 3.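

In this assay, this carbon turns out to be sensitive to which group it carries, not only to whether it carries one: methoxy in place of methyl gives a 10-fold lower number from compound 1 to compound 4 (1.00 log units; beyond the scatter) and methoxy in place of butylamino gives a 10-fold lower number from compound 2 to compound 4 (1.00 log units; beyond the scatter) even though methyl and butylamino had stood level. Methoxy in place of hydrogen gives a 100-fold lower number from compound 3 to compound 4 (2.00 log units; beyond the scatter) and is the largest step among the new ones, so the full span at this carbon is wider than the earlier compounds suggested, with less compound needed for the effect once methoxy is present. No measurement on hand explains why methoxy differs from methyl and butylamino here.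

The compounds shown leave open whether this advantage belongs to methoxy alone or also appears with an ethoxy group, a longer alkoxy chain such as butoxy, or a hydroxyl group at this carbon. They also leave open whether a small amine such as methylamino or a halogen such as chlorine would fall with methoxy or with methyl and butylamino, since butylamino is the only amine at this carbon so far.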